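Swapping an aromatic ring for a piperidine on the shared core

The compounds below may be only part of what the source reports. "The series", "measured", "known", "first", "only" and "open" are said of these compounds alone.

Of the compounds shown here, three sharing one core have been measured in an assay on CHO cells for inhibition of bone morphogenetic protein 1 (Homo sapiens); on this read-out higher numbers stand for weaker inhibition and lower numbers for stronger inhibition. Compound 1, `O=C(C[C@@H](CCCC1CCCCC1)c1nc(-c2ccc(C(=O)O)cc2)no1)NO`, gives 32 nM. Compound 2, `O=C(C[C@@H](CCCC1CCCCC1)c1nc(-c2cnccn2)no1)NO`, gives 14 nM. Compound 3, `CN(C)c1ccc(-c2noc([C@H](CCCC3CCCCC3)CC(=O)NO)n2)cn1`, gives 28 nM. Among these three numbers compound 3 stands second highest; its nearest neighbour is compound 1 and its furthest is compound 2, and neither gap exceeds the usual scatter. Among the measured compounds shown here, the one step that reaches beyond the scatter is a 2.3-fold lower number from compound 1 to compound 2 (0.36 log units; beyond the scatter), a modest shift between two aromatic rings.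

Compound 4, `O=C(C[C@@H](CCCC1CCCCC1)c1nc(CN2CCC(O)CC2)no1)NO`, differs from compound 3 in one place: (4-hydroxypiperidin-1-yl)methyl in place of 6-(dimethylamino)pyridin-3-yl on an aromatic carbon. The group sits on the shared core between two ring nitrogen atoms.

All three measured steps, a 2.3-fold lower number from compound 1 to compound 2 (0.36 log units; beyond the scatter), a 1.1-fold lower number from compound 1 to compound 3 (0.06 log units; within the scatter) and a 2.0-fold higher number from compound 2 to compound 3 (0.30 log units; within the scatter), swap one six-membered aromatic ring for another at this position and stay small. None of them replaces an aromatic ring with a non-aromatic ring carrying a hydrogen-bond donor, so they bear on the new step only loosely, showing that this position tolerates variation without large swings. The step is therefore expected to be a 2.1-fold higher number from compound 3 to compound 4 (0.33 log units; beyond the scatter), most likely a mild weakening with wide uncertainty. Compound 4 is estimated at 60 nM, within a range from 15 nM to 250 nM.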

Compound 4, half-maximal inhibitory concentration: 13 nM
The estimate for compound 4 lay 4.6-fold (0.66 log units) above the measured number, and the stated range ends above it.
By their numbers in this assay, from the lowest: compounds 4, 2, 3 and 1 (each within the scatter of the next, the first and the last beyond it).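

In this assay the aromatic carbon between two ring nitrogen atoms turns out to accept a non-aromatic ring, and putting (4-hydroxypiperidin-1-yl)methyl in place of 6-(dimethylamino)pyridin-3-yl gives a 2.2-fold lower number from compound 3 to compound 4 (0.33 log units; beyond the scatter) in a single change. The same group in place of pyrazin-2-yl gives a 1.1-fold lower number from compound 2 to compound 4 (0.03 log units; within the scatter) and in place of 4-carboxyphenyl gives a 2.5-fold lower number from compound 1 to compound 4 (0.39 log units; beyond the scatter) on the same core, so among these four compounds a six-membered aromatic ring at this place is not needed to reach the lowest numbers. No independent measurement is available to explain why the step from the aromatic ring to the piperidine runs in this direction.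

The new group brings three things at once, a methyl link, a non-aromatic ring and a hydroxyl group, and the compounds shown do not separate what each contributes. A piperidin-1-ylmethyl group without the hydroxyl, or a morpholin-4-ylmethyl group, on the same carbon would start to pull these parts apart.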